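This account rests on a few compounds, and the source may have more. Where it says the series, first, only, none or still open, it means among the compounds named here.

Compound 1 `Cc1cn([C@H]2S[C@@H](CO)C=C2F)c(=O)[nH]c1=O` and compound 2 `Nc1nc(O)c2ncn([C@H]3S[C@@H](CO)C=C3F)c2n1` share the same core and differ only in the base. In a functional assay on Vero cells (Chlorocebus sabaeus) (on this read-out higher numbers stand for weaker inhibition and lower numbers for stronger inhibition), compound 1 reaches only a limit of the assay, > 100000 nM, not a number. In this assay compound 2 gives 66400 nM. Compound 1 thus stands at the limit of > 100000 nM in this assay, at which 1 of the 2 values shown sits. Compound 3 `O=c1ccn([C@H]2S[C@@H](CO)C=C2F)c(=O)[nH]1` has not yet been tested; it differs from compound 1 by hydrogen in place of methyl on an aromatic carbon. Among the measured compounds shown here, no measured step of this kind is available to gauge such a change. The expected step is a number no higher from compound 1 to compound 3 (the limit leaves the size open), within the scatter. Compound 3 is estimated at 100000 nM, between 30000 nM and 300000 nM, most likely again only a limit.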

Compound 3, half-maximal inhibitory concentration: > 100000 nM
Compound 3 gave a limit, no number; the forecaster's own chance of this, stated with the estimate: 60%; the middle value lies on the limit itself.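

Compound 1 and compound 3 both end at a limit of the assay rather than a number, so no step between them can be read: the limit of > 100000 nM in this assay, at which 2 of the 3 values shown sit.

Going by these compounds, whether hydrogen in place of methyl on an aromatic carbon changes inhibition at all stays open.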